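Sulfamoyl carbamates and sulfamate carbamates: aryl for cyclohexyl

A few compounds are considered here, and "the series" means these few. Any claim that something is new, unique, unknown or untested is made for them only; others in the source may bear on it.

Measured compounds:
compound 1 `CC(C)c1cccc(C(C)C)c1OC(=O)NS(=O)(=O)N(C(C)C)C(C)C` — 15000 nM
compound 2 `CCCCN(CCCC)S(=O)(=O)NC(=O)Oc1c(C(C)C)cccc1C(C)C` — 1900 nM; 1900 nM (2 entries)
compound 3 `CC(C)c1cccc(C(C)C)c1OS(=O)(=O)NC(=O)OC1CCCCC1` — 38000 nM

In an assay on liver for inhibition of sterol O-acyltransferase 1 (Rattus norvegicus), using microsomes (on this read-out lower numbers stand for stronger inhibition and higher numbers for weaker inhibition), compound 3 gives 38000 nM, the highest number among the compounds with a single value; compound 1 gives 15000 nM in this assay, a lower number by a step beyond the scatter. Among the compounds with values here, compound 2 carries two entries in this assay, both at 1900 nM; 1900 nM (2 entries), and these are the lowest numbers recorded; no step between compound 2 and either of the other two is mapped, so only the values themselves can be compared.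

Compound 4 `Cc1cccc(C)c1OC(=O)NS(=O)(=O)Oc1c(C(C)C)cccc1C(C)C` is not yet measured. It differs from compound 3 in one place: 2,6-dimethylphenyl in place of cyclohexyl on an oxygen next to a carbonyl group. Within the data shown here, no measured pair isolates this change, so the expectation rests on the spread seen so far rather than on a mapped step. A modest move toward a lower number is expected, of a size that may not clear the scatter, giving a 1.9-fold lower number from compound 3 to compound 4 (0.28 log units; within the scatter). For compound 4 the estimate in this assay is 20000 nM, with a range from 5000 nM to 80000 nM.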

Compound 4, half-maximal inhibitory concentration: > 50000 nM
Compound 4: no number, only a limit; the forecaster's own chance of this, stated with the estimate: 15%; middle value at least 2.5-fold (0.39 log units) away from the limit.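

In this assay compound 4 gives > 50000 nM, which is a limit of the assay and not a number: the limit of > 50000 nM in this assay, at which 1 of the 4 values shown sits. Within the data shown here, compound 3 and compound 4 form the first mapped pair, and 2,6-dimethylphenyl in place of cyclohexyl on an oxygen next to a carbonyl group reads as an at least 1.3-fold higher number from compound 3 to compound 4 (0.11 log units; that floor lies within the scatter). The step shows that this aromatic ring gives no lower number at this position, though its floor alone does not fix how far the number rises.

From the compounds shown here alone, the full size of the step stays unknown, since only its floor can be read. Also open, going by these compounds, is how a plain phenyl or a straight octyl chain on this oxygen would read in this assay, and whether either would come closer to compound 2 at 1900 nM; 1900 nM (2 entries).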